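A few compounds are considered here, and "the series" means these few. Any claim that something is new, unique, unknown or untested is made for them only; others in the source may bear on it.

Compound 3 `COc1ccc(C2=NN(C3=NC(=O)/C(=C4\C(=O)Nc5ccc(Br)cc54)S3)C(c3ccc(Cl)cc3)C2)cc1` gives 180 nM in a functional assay on cells (Cancer cell lines, Homo sapiens) for cytotoxicity, read by sulforhodamine B assay, with a stated time of 48 h (on this read-out higher numbers stand for weaker inhibition of growth and lower numbers for stronger inhibition of growth), the lowest of the three numbers measured. Compound 1 `COc1ccc(C2=NN(C3=NC(=O)/C(=C4\C(=O)Nc5ccc(Cl)cc54)S3)C(c3ccc(OC)cc3)C2)cc1` gives 250 nM in this assay, which lies within the scatter of compound 3. Compound 2 `COc1ccc(C2=NN(C3=NC(=O)/C(=C4\C(=O)Nc5ccccc54)S3)C(c3ccc(Cl)cc3)C2)cc1` gives 100000 nM in this assay. Among the compounds with values here, only one measured step touches the site in question: a 560-fold lower number from compound 2 to compound 3 (2.74 log units; beyond the scatter), where a halogen is added to the hydrogen-bearing ring position. Compound 4 `COc1ccc(C2=NN(C3=NC(=O)/C(=C4\C(=O)Nc5ccc(Cl)cc54)S3)C(c3ccc(Cl)cc3)C2)cc1` differs from compound 3 only by chloro in place of bromo on an aromatic carbon, so one halogen is swapped for another at a spot already occupied. Compound 1, which also carries chloro at that place, gives a number close to compound 3. The expected step of a 1.2-fold higher number from compound 3 to compound 4 (0.09 log units; within the scatter) is therefore small, not beyond the scatter. Compound 4 is estimated at 220 nM, within 80 nM to 600 nM.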

Compound 4, concentration for 50% growth inhibition: 270 nM
The estimate for compound 4 lay 1.2-fold (0.09 log units) below the measured number, within the range that was stated.
By their numbers in this assay, from the lowest: compounds 3, 1 and 4 (each within the scatter of the next); then compound 2.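

In this assay, swapping one halogen for the other at this place changes little, with a 1.5-fold higher number from compound 3 to compound 4 (0.18 log units; within the scatter) staying within the scatter. The large fall in the number first seen with bromo returns with chloro, as a 370-fold lower number from compound 2 to compound 4 (2.57 log units; beyond the scatter) shows, so at this place it does not depend on bromine alone. Elsewhere in the molecule, exchanging one group for another is also a small step, with a 1.1-fold higher number from compound 1 to compound 4 (0.03 log units; within the scatter) within the scatter.

On these data alone, whether fluoro, methyl or an amine at this place would also give a low number stays open. No measurement shown explains why a halogen here matters so much.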